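The source may report more compounds than this note shows. Statements on the series, on what has been measured and on what is new or still open speak of the compounds shown alone.

Compounds measured in an assay on isolated protein for inhibition of 3-hydroxy-3-methylglutaryl-coenzyme A reductase (Homo sapiens); a lower number here means a stronger inhibitor, a higher number a weaker inhibitor:
compound 1, `CC(C)c1cc(-c2ccc(F)cc2)c(-c2ccc(F)cc2)n1/C=C/[C@@H](O)C[C@@H](O)CC(=O)O`, 8.7 nM; 6.98 nM (2 entries)
compound 2, `CC(C)c1cc(-c2cccc(Br)c2)c(-c2ccc(F)cc2)n1/C=C/[C@@H](O)C[C@@H](O)CC(=O)O`, 9.3 nM

Among the measured compounds shown here, compound 2 holds the only number recorded for it in this assay; a further entry for it gives no single figure. Set against compound 1, whose repeat entries are gathered in the several entries of compound 1 in this assay, 8.7 nM; 6.98 nM (2 entries), the value of compound 2 lies within the usual scatter of such measurements, so the two compounds cannot be told apart on these numbers.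

Compound 3, `CC(C)c1cc(-c2ccncc2)c(-c2ccc(F)cc2)n1/C=C/[C@@H](O)C[C@@H](O)CC(=O)O`, has not yet been measured. It differs from compound 2 by pyridin-4-yl in place of 3-bromophenyl on an aromatic carbon. For the measured compounds named here, no comparable step between measured compounds is available, so the expectation rests only on the closeness of compound 1 and compound 2. In this assay the step of a 1.6-fold higher number from compound 2 to compound 3 (0.21 log units; within the scatter) is expected to be small, leaning toward a weaker inhibitor, and may not exceed the scatter. Compound 3 is accordingly estimated at 15 nM, with a range of 5 nM to 45 nM.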

Compound 3, half-maximal inhibitory concentration: 8.3 nM
Beside the measured number, compound 3's estimate is 1.8-fold (0.26 log units) above it; the range from low to high includes it.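

In this assay, replacing 3-bromophenyl with pyridin-4-yl gives a 1.1-fold lower number from compound 2 to compound 3 (0.05 log units; within the scatter), so this position on the aromatic carbon holds a six-membered aromatic ring with a hetero atom as well as one of carbon only. The earlier compounds shown here carried only halogen-bearing rings of carbon here, whereas compound 3 has no halogen and adds a hydrogen-bond acceptor, yet no difference can be read from this change. The repeat entries of one compound show how far values for the same structure can lie apart: the several entries of compound 1 in this assay, 8.7 nM; 6.98 nM (2 entries)

From the compounds shown here alone, whether an amine, a carboxylic acid or a longer chain at this position would leave the number unchanged remains open. So does the effect of moving the ring nitrogen, as in pyridin-3-yl or pyridin-2-yl.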